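Oxazole in place of the propylcarbonyl on the dihydropyrimidinone core

The source may report more compounds than this note shows. Statements on the series, on what has been measured and on what is new or still open speak of the compounds shown alone.

Of the compounds shown here, two have been measured in an assay on membranes from HEK293 cells for displacement of a labelled ligand from adenosine receptor A2b (Homo sapiens), read by scintillation counting, with a stated time of 30 min, tested at 1 uM; on this read-out higher numbers stand for more inhibition at the one concentration tested (going by the name of the read-out) and lower numbers for less inhibition. Compound 1 `CC1=C(C(=O)OC(C)(C)C)C(c2cccs2)NC(=O)N1` gives 38%. Within the data shown here, compound 2 `CCCC(=O)C1=C(C)NC(=O)NC1c1cccs1` gives 9%, the lower of the two numbers; the only measured step, a number 29 percentage points lower from compound 1 to compound 2 (beyond the scatter), is the change from compound 1 to compound 2, and it shows that swapping the group on the carbonyl carbon at this ring position moves the read-out by a modest amount.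

Compound 3 `CC1=C(c2ncc(C)o2)C(c2cccs2)NC(=O)N1` is not yet measured. The change from compound 2 is 5-methyl-1,3-oxazol-2-yl in place of propylcarbonyl on a double-bonded ring carbon. Among the measured compounds shown here, no step between measured compounds involves an aromatic ring at this position, so the step to compound 3 can only be judged from compound 2 alone. For the measured compounds named here, because the one change at this position, a number 29 percentage points lower from compound 1 to compound 2 (beyond the scatter), was modest, a step of similar size in either direction is the working assumption, and with compound 2 already low the larger room lies upward. Compound 3 is therefore estimated at 20% in this assay, with a range of 0% to 45%, meaning an expected step of a number 11 percentage points higher from compound 2 to compound 3 (beyond the scatter).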

Compound 3, a percentage reported as inhibition, at one concentration (the size of the read-out at that concentration, not a potency): 45%
Compound 3: middle estimate off by 25 percentage points, on the low side, and the stated range covers the measured number.
By their numbers in this assay, from the lowest: compound 2; then compounds 1 and 3 (each within the scatter of the next).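

In this assay, the change to 5-methyl-1,3-oxazol-2-yl gives a number 36 percentage points higher from compound 2 to compound 3 (beyond the scatter), so this place on the double-bonded ring carbon accepts a five-membered aromatic ring, and the read-out here can rise as well as fall. The printed numbers of compound 1 and compound 3 lie within the scatter of each other, so a carbonyl directly on this ring carbon is not needed to reach this level. The data offer no explanation for the size of this step.

Still open, from the compounds shown here alone, is how much of the step belongs to the methyl on the oxazole and how much to the ring itself, which an unsubstituted oxazol-2-yl, a thiazol-2-yl or a phenyl at this place would help separate. Also open, going by these compounds, is whether the step holds when phenyl stands in place of thiophen-2-yl.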